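The source may report more compounds than this note shows. Statements on the series, on what has been measured and on what is new or still open speak of the compounds shown alone.

Compound 1 `O=CNc1ccc(C2=NNC(=O)CC2)cc1` holds the lowest value of the two compounds measured in a functional assay for inhibition, with Homo sapiens as the target; on this read-out lower numbers stand for an effect already at smaller amounts and higher numbers for an effect only at larger amounts of compound: compound 1 gives 3.74 ug/mL. Compound 2 `CC1CC(c2ccc(N)cc2)=NNC1=O` gives 43.8 ug/mL in this assay; these two compounds differ in more than one place, so no single step can be read between them. Compound 3 `C=CCNCC(=O)Nc1ccc(C2=NNC(=O)CC2)cc1` is not yet measured; it differs from compound 1 by (allylamino)methyl in place of hydrogen on a carbonyl carbon. Within the data shown here, no measured pair shows a change of this kind, so the size of the step is open; a small step, close to the scatter, is expected. For compound 3 the expected value in this assay is 6 ug/mL, with a range of 1.5 ug/mL to 25 ug/mL. The expected step is a 1.6-fold higher number from compound 1 to compound 3 (0.21 log units; within the scatter).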

Compound 3, half-maximal effective concentration: about 21.5 ug/mL
The estimate for compound 3 lay 3.6-fold (0.55 log units) below the measured number; the measured number falls inside the stated range.
By their numbers in this assay, from the lowest: compound 1; then compound 3; then compound 2.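

In this assay, among these compounds, (allylamino)methyl in place of hydrogen on a carbonyl carbon gives a 5.7-fold higher number from compound 1 to compound 3 (0.76 log units; beyond the scatter) and so provides the first read step at this position. On this carbonyl carbon, whose other neighbour is the amide-type nitrogen, the change is not neutral: the step lies beyond the scatter and runs toward a higher number. Nothing at hand gives a reason for the step.

Open, going by these compounds, is whether a methyl or a plain aminomethyl at this place stays closer to compound 1. Also open, on these data alone, is whether a longer chain or a carboxylic acid there moves the number further.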